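The compounds below may be only part of what the source reports. "The series", "measured", "known", "first", "only" and "open" are said of these compounds alone.

Compound 1 `CC(C)CCOc1ccccc1C1CC(=O)c2ccccc2O1` gives 43.6% in a functional assay on J774.A1 cells (Mus musculus) for inhibition, read by immunoassay, with a stated time of 12 h, tested at 30 uM; a lower number here means less inhibition, a higher number more inhibition at the concentration tested (going by the name of the read-out).
Compound 2 `CC(C)=CCOc1ccccc1C1CC(=O)c2ccccc2O1` gives 40.3% in this assay.
Compound 3 `COc1ccccc1C1CC(=O)c2ccccc2O1` gives 38.3% in this assay.

Compound 3 sits lowest of the three, yet the gaps separating it from the others, a number 5.3 percentage points lower from compound 1 to compound 3 (within the scatter) and a number 2 percentage points lower from compound 2 to compound 3 (within the scatter), both fall within the scatter, so nothing here orders the three. Compound 4 `COCOc1ccccc1C1CC(=O)c2ccccc2O1` differs from compound 3 by methoxy in place of hydrogen on a saturated chain carbon bound to an oxygen on an aromatic ring. The two measured steps at that same place, where isobutyl and 2-methylprop-1-en-1-yl were each replaced by hydrogen, are the ones that bear on this change, and neither moved the number beyond the scatter. On that basis compound 4 is expected to show a step of a number 1.7 percentage points higher from compound 3 to compound 4 (within the scatter) in this assay, no real movement. Compound 4 is estimated at 40%, within 28% to 52%.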

Compound 4, a percentage reported as inhibition, at one concentration (the size of the read-out at that concentration, not a potency): 33.3%
Compound 4: the middle estimate sits 6.7 percentage points above what was measured; measured number inside the range.
By their numbers in this assay, from the lowest: compounds 4, 3, 2 and 1 (each within the scatter of the next, the first and the last beyond it).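

At this position, on a saturated chain carbon bound to an oxygen on an aromatic ring, methoxy in place of hydrogen stays within the scatter in this assay (a number 5 percentage points lower from compound 3 to compound 4 (within the scatter)), as does methoxy in place of 2-methylprop-1-en-1-yl (a number 7 percentage points lower from compound 2 to compound 4 (within the scatter)). Methoxy in place of isobutyl gives the first step at this place to pass the scatter, and only modestly (a number 10.3 percentage points lower from compound 1 to compound 4 (beyond the scatter)). Nothing measured here accounts for this separation.

On these data alone, whether an amine or a carboxylic acid at this place would shift the number beyond the scatter stays open, as does the effect of a chain longer than isobutyl.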